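A few compounds are considered here, and "the series" means these few. Any claim that something is new, unique, unknown or untested is made for them only; others in the source may bear on it.

Compound 3 `CC(C)OC(=O)C1=C(S[C@@H]2CN[C@H](C(=O)Nc3cccc(C(=O)O)c3)C2)[C@H](C)[C@@H]2[C@@H]([C@@H](C)O)C(=O)N12` carries an isopropyl group on an oxygen next to a carbonyl group. In an ADME assay for metabolic stability, read by LC-MS, with a stated time of 3 h, at pH 6.5, tested at 50 uM (on this read-out lower numbers stand for a less stable compound and higher numbers for a more stable compound), compound 3 gives a reading of > 95%, which is a limit of the assay rather than a number. Compound 1 `C[C@@H](O)[C@H]1C(=O)N2C(C(=O)OCOC(=O)C(C)(C)C)=C(S[C@@H]3CN[C@H](C(=O)Nc4cccc(C(=O)O)c4)C3)[C@H](C)[C@H]12` and compound 2 `CC(C)OC(=O)OCOC(=O)C1=C(S[C@@H]2CN[C@H](C(=O)Nc3cccc(C(=O)O)c3)C2)[C@H](C)[C@@H]2[C@@H]([C@@H](C)O)C(=O)N12` carry longer groups in the same place. In this assay compound 1 gives > 95%, again a limit of the assay. In this assay compound 2 reaches > 95%, also a limit. All three readings sit together at one limit, (the limit of > 95% in this assay, at which 3 of the 3 values shown sit), so the steps among them cannot be sized: a step that the two limits leave unreadable from compound 1 to compound 3, a step that the two limits leave unreadable from compound 2 to compound 3 and a step that the two limits leave unreadable from compound 1 to compound 2. Compound 4 `CC(C)C(=O)OCOC(=O)C1=C(S[C@@H]2CN[C@H](C(=O)Nc3cccc(C(=O)O)c3)C2)[C@H](C)[C@@H]2[C@@H]([C@@H](C)O)C(=O)N12` has not yet been tested. It differs from compound 3 in one place: ((isopropylcarbonyl)oxy)methyl in place of isopropyl on an oxygen next to a carbonyl group. The two measured swaps of this kind, at the same oxygen, left the reading at the limit, and compound 1 and compound 2 show that a larger group in this position is compatible with that limit. The step from compound 3 to compound 4 is therefore expected to be none beyond the scatter: a step that the limit leaves unreadable from compound 3 to compound 4. Compound 4 is estimated at 96%, within a range from 85% to 100%, and will most likely again be reported only as a limit.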

Compound 4, percent of the compound remaining: > 95%
Compound 4: only a limit was reported (the forecaster's own chance of this, stated with the estimate: 85%); the middle value lies beyond the limit too.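

Among these compounds, compound 4 sits at the same limit as compound 1, compound 2 and compound 3 in this assay, so no step between compound 4 and any of them can be read: the limit of > 95% in this assay, at which 4 of the 4 values shown sit. The compounds shown leave open how far these four actually differ in this read-out, and whether the group on this oxygen changes the reading at all.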